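A few compounds are considered here, and "the series" means these few. Any claim that something is new, unique, unknown or untested is made for them only; others in the source may bear on it.

Measured compounds:
compound 1 `Nc1nc(N/N=C/c2cncs2)nc2c1ncn2[C@@H]1O[C@H](CO)[C@@H](O)[C@H]1O` — in an assay on CHO-K1 cells for displacement of a labelled ligand from adenosine receptor A1 (Homo sapiens), read by scintillation counting, with a stated time of 60 min (a higher number here means a weaker inhibitor, a lower number a stronger inhibitor), compound 1 gives 22 nM.
compound 2 `Nc1nc(N/N=C/c2ccc(-c3ccccn3)cc2)nc2c1ncn2[C@@H]1O[C@H](CO)[C@@H](O)[C@H]1O` — in this assay compound 2 gives 7540 nM.
compound 3 `COc1cc(/C=N/Nc2nc(N)c3ncn([C@@H]4O[C@H](CO)[C@@H](O)[C@H]4O)c3n2)cc(OC)c1OC` — in this assay compound 3 gives > 10000 nM, a limit of the assay and not a number.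

Compound 1 stands at the lowest of the two numbers shown; compound 2 sits far higher, a gap well beyond the usual scatter. Compound 3 reaches only (the limit of > 10000 nM in this assay, at which 1 of the 3 values shown sits). Both weaker compounds carry a six-membered aromatic ring of carbon only on the carbon with a double bond to nitrogen, where compound 1 carries 1,3-thiazol-5-yl; with three compounds no wider pattern is claimed.

Compound 4 `Nc1nc(N/N=C/c2ccc(Cl)c(C(F)(F)F)c2)nc2c1ncn2[C@@H]1O[C@H](CO)[C@@H](O)[C@H]1O` is not yet measured. It differs from compound 1 in one place: 4-chloro-3-(trifluoromethyl)phenyl in place of 1,3-thiazol-5-yl on a carbon with a double bond to nitrogen. The entering group is again a six-membered aromatic ring of carbon only, the kind of ring found in compound 2 with its value of 7540 nM. Compound 4 is therefore expected to be weaker in this assay than compound 1, by an expected step of a 110-fold higher number from compound 1 to compound 4 (2.06 log units; beyond the scatter). The estimate for compound 4 is 2500 nM, with a range from 300 nM to 10000 nM.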

Compound 4, inhibition constant: > 10000 nM
Compound 4: a limit, no number; the forecaster's own chance of this, stated with the estimate: 25%; at least 4.0-fold (0.60 log units) between middle value and limit.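

Putting 4-chloro-3-(trifluoromethyl)phenyl in place of 1,3-thiazol-5-yl on a carbon with a double bond to nitrogen gives an at least 450-fold higher number from compound 1 to compound 4 (2.65 log units; beyond the scatter) in this assay, the first step read at this place in the series. The step is large, so this place is not indifferent to the group it carries, and the two substituents on the six-membered ring of carbon only do not bring back the value of compound 1. The result for compound 4 is a limit and not a number, and compound 3 stands at the same limit: the limit of > 10000 nM in this assay, at which 2 of the 4 values shown sit.

This single step changes the ring, its hetero atoms and its substituents together, so the compounds shown do not separate their contributions. As far as these compounds go, how a plain phenyl, a thiophen-2-yl or a pyridin-3-yl would stand at this place remains open.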